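The source may report more compounds than this note shows. Statements on the series, on what has been measured and on what is new or still open speak of the compounds shown alone.

Compound 1 `COc1cccc(-c2ccc(C(=O)N(Cc3cccc(OCCCCCC(=O)O)c3)C(C)C)cc2)c1` was examined in an ADME assay on HEK293 cells (Homo sapiens) for cytotoxicity, read by CellTiter-Glo and resazurin assay, with a stated time of 72 h; a lower number here means that less compound is needed, a higher number that more compound is needed for the effect. In this assay compound 1 gives only a limit, > 20900 nM. Compound 2 `CC(C)N(Cc1cccc(OCCCCCC(=O)O)c1)C(=O)c1ccc(-c2ccc3[nH]ccc3c2)cc1` carries 1H-indol-5-yl in place of 3-methoxyphenyl on an aromatic carbon. In this assay compound 2 also gives only a limit, > 26000 nM. The step from compound 1 to compound 2 is a step that the two limits leave unreadable from compound 1 to compound 2, a result that rests on the limit of > 20900 nM in this assay, at which 1 of the 3 values shown sits, and (the limit of > 26000 nM in this assay, at which 1 of the 3 values shown sits).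

Compound 3 `CCOC(=O)CCCCCOc1cccc(CN(C(=O)c2ccc(-c3cccc(OC)c3)cc2)C(C)C)c1` differs from compound 1 by ethyl in place of hydrogen on an oxygen next to a carbonyl group; this is also how the cores of the two pairs differ. In this assay compound 3 gives only a limit, > 21000 nM. The step from compound 1 to compound 3 is a step that the two limits leave unreadable from compound 1 to compound 3, with compound 3 sitting at the limit of > 21000 nM in this assay, at which 1 of the 3 values shown sits.

Compound 4 `CCOC(=O)CCCCCOc1cccc(CN(C(=O)c2ccc(-c3ccc4[nH]ccc4c3)cc2)C(C)C)c1` has not yet been measured. It differs from compound 3 by 1H-indol-5-yl in place of 3-methoxyphenyl on an aromatic carbon, the same change, at the same place, as that from compound 1 to compound 2. The step from compound 3 to compound 4 is expected to be a step that the limit leaves unreadable from compound 3 to compound 4, an expectation resting on compound 3 giving only a limit, > 21000 nM. Compound 4 is therefore expected to give 25000 nM, with a range from 15000 nM to 60000 nM.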

Compound 4, half-maximal effective concentration: > 26000 nM
Compound 4 ended at the assay's limit; the forecaster's own chance of this, stated with the estimate: 85%; at least 1.0-fold (0.01 log units) between middle value and limit.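

In this assay compound 4 gives only a limit, > 26000 nM. Compound 2 and compound 3 also give only limits, so neither step, from compound 3 or from compound 2 to compound 4, can be read. The compounds shown leave open where any of the four would reach its half-maximal effect in this assay, and whether either change shifts it.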